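A few compounds are considered here, and "the series" means these few. Any claim that something is new, unique, unknown or untested is made for them only; others in the source may bear on it.

Compound 1, `CSc1ccc(C)cc1NCC1=NCCN1`, is the point of departure. In a functional assay for agonist activity at Alpha-1B adrenergic receptor (Homo sapiens) (on this read-out lower numbers stand for an effect already at smaller amounts and higher numbers for an effect only at larger amounts of compound), compound 1 gives 0.417 nM, the lowest of the two numbers reported for this read-out. Among the compounds with values here, its nearest neighbour is compound 3, `Cc1ccc(S(C)(=O)=O)c(NCC2=NCCN2)c1`, which in this assay gives 141 nM; the single measured step, a 340-fold higher number from compound 1 to compound 3 (2.53 log units; beyond the scatter), is a large one. Compound 2, `CS(=O)(=O)c1cccc(F)c1NCC1=NCCN1`, is reported in this assay only as a limit, < 100000 nM, and not as a number. Within the data shown here, the limit line the limit of < 100000 nM in this assay, at which 1 of the 3 values shown sits, is the one piece of supporting evidence on the measured steps, and it concerns compound 2 alone.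

The step now followed leads from compound 1 to compound 4, `COc1ccc(SC)c(NCC2=NCCN2)c1`. The change is methoxy in place of methyl on an aromatic carbon. Among the measured compounds shown here, none of the measured steps bears on this change: the only step in hand alters the methylsulfanyl group, while here the methylsulfanyl group stays and the methyl group is swapped for a methoxy group. For the measured compounds named here, with no step of the same kind to lean on, a modest change in this assay is expected, in either direction, and probably not far beyond the scatter. Compound 4 is therefore estimated at 0.9 nM, within a range from 0.2 nM to 5 nM, which would mean a step of a 2.2-fold higher number from compound 1 to compound 4 (0.33 log units; beyond the scatter).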

Compound 4, half-maximal effective concentration: 3.63 nM
Compound 4: middle estimate off by 4.0-fold (0.61 log units), on the low side; the range from low to high includes it.
By their numbers in this assay, from the lowest: compound 1; then compound 4; then compound 3.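

In this assay, the position para to the methylsulfanyl group, which the earlier step left untouched, proves sensitive to substitution: methoxy in place of methyl gives an 8.7-fold higher number from compound 1 to compound 4 (0.94 log units; beyond the scatter). This change on the aromatic carbon is the smaller of the two single-place changes made to compound 1, the other being methylsulfonyl in place of methylsulfanyl, which gives a 340-fold higher number from compound 1 to compound 3 (2.53 log units; beyond the scatter). The position therefore tolerates this swap with a modest rise in the number, and the methylsulfanyl compounds remain in the low range of this read-out, but nothing shown here explains why the rise occurs.

The compounds shown leave open whether the rise is specific to methoxy or would also appear with other groups at this position, such as an amine, a hydroxyl, or a longer chain like ethoxy. They also leave open whether methoxy at this position would bring a step of similar size in a compound carrying methylsulfonyl instead of methylsulfanyl, so the two changes cannot yet be said to act independently of each other.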